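A few compounds are considered here, and "the series" means these few. Any claim that something is new, unique, unknown or untested is made for them only; others in the source may bear on it.

In a functional assay on HEK293 cells with D(4) dopamine receptor (Homo sapiens) as the target, read by FLIPR (a higher number here means that more compound is needed for the effect, a lower number that less compound is needed), two compounds have been measured so far. Compound 1, with the structure `CO/N=C(\CCN1CCN(c2ccccn2)CC1)c1ccc(Cl)cc1`, gives 37.6 nM. Compound 2, with the structure `CO/N=C(\c1ccc(Cl)cc1)C(CN1CCN(c2ccccn2)CC1)OC`, gives 195 nM. Among the compounds with values here, compound 2 thus stands at the higher of the two numbers, and the only neighbour for comparison is compound 1, whose number is lower by a margin that lies beyond the usual scatter. Within the data shown here, compound 1 and compound 2 differ in more than one place, so their two values show only that compound 2 needs more material for the same effect; no single structural cause can be read from them.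

Compound 3, with the structure `CO/N=C(/c1ccc(Cl)cc1)C(CN1CCN(c2ccccn2)CC1)OC`, is the next step. Its change from compound 2 is this: the two compounds have the same atoms and bonds; at least one stereo element is drawn with a configuration in one of them and without one in the other: 1 of 2 stereo elements differ; a double bond is drawn E in compound 2 and Z in compound 3. In words, the two compounds have the same atoms and bonds, and only the geometry drawn at one double bond is switched from E to Z.

No measured pair here isolates such a geometry switch, so the size and direction of its effect in this assay cannot be taken from the data shown. Isomers of this kind are often separated by a clear gap in either direction, so a step beyond the scatter is plausible, but it could equally fall within it. The expected value for compound 3 is 250 nM, within a range from 50 nM to 1500 nM, which means an expected step of a 1.3-fold higher number from compound 2 to compound 3 (0.11 log units; within the scatter).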

Compound 3, half-maximal effective concentration: 285 nM
For compound 3 the middle estimate is 1.1-fold (0.06 log units) below the measured one; the measured number falls inside the stated range.
By their numbers in this assay, from the lowest: compound 1; then compounds 2 and 3 (each within the scatter of the next).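

In this assay, the switch of the double bond from E to Z gives a 1.5-fold higher number from compound 2 to compound 3 (0.16 log units; within the scatter), so with the methoxy in place, the drawn geometry at this double bond leaves no gap that can be told from ordinary repeat variation. The other comparison isolates a change that the opening pair could not, with methoxy in place of hydrogen on a saturated chain carbon bound to a carbon with a double bond to nitrogen and a saturated chain carbon: it gives a 7.6-fold higher number from compound 1 to compound 3 (0.88 log units; beyond the scatter), so this chain position, unlike the geometry of the double bond, shows a clear step, with more compound needed once the methoxy is present. The geometry comparison still needs care, and the reason for reading it cautiously is this: the fact that one of compounds 2 and 3 is drawn with a defined configuration and the other without, at the place where they differ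

From the compounds shown here alone, it remains open whether a hydroxyl, a methyl or an ethoxy at the same chain carbon would give a similar step to that of the methoxy. Going by these compounds, it is also open whether the geometry switch would stay as small in a compound carrying hydrogen at that carbon, and whether the configuration at that carbon matters.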